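The source may report more compounds than this note shows. Statements on the series, on what has been measured and on what is new or still open speak of the compounds shown alone.

Compound 1 `Clc1ccc(-c2ccc(Cn3nnc4ccccc43)cc2)c(Cl)c1`: 79 nM
Compound 2 `Brc1cccc2c1nnn2CC1CC1`: 70 nM

Of the compounds shown here, two have been measured in a functional assay on cells for positive allosteric modulation of metabotropic glutamate receptor 2 (Homo sapiens), read by fluorescence and calcium flux, with a stated time of 30 min; on this read-out lower numbers stand for an effect already at smaller amounts and higher numbers for an effect only at larger amounts of compound. In this assay compound 1 gives 79 nM, and compound 2 gives 70 nM. Compound 2 has the lower of the two numbers, but the gap between compound 2 and compound 1 lies within the scatter of the measurement, so the two compounds cannot be told apart on these values, and neither can be called the more potent. Among the measured compounds shown here, the two compounds share no common core, so no single structural step between them can be read off.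

Compound 3 `CCCn1nnc2c(Br)cccc21` has not yet been measured. It differs from compound 2 in one place: ethyl in place of cyclopropyl on a saturated chain carbon bound to an aromatic nitrogen. For the measured compounds named here, no measured pair shows the effect of this kind of change, so the expectation rests on the change alone; a small exchange of this sort is expected to give no step beyond the scatter in this assay, in either direction. The step from compound 2 to compound 3 is therefore estimated as a 1.4-fold higher number from compound 2 to compound 3 (0.15 log units; within the scatter). For compound 3 the expected value in this assay is 100 nM, with a range from 35 nM to 300 nM.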

Compound 3, half-maximal effective concentration: 270 nM
Compound 3: the middle estimate sits 2.7-fold (0.43 log units) below what was measured; the measured number falls inside the stated range.
By their numbers in this assay, from the lowest: compounds 2 and 1 (each within the scatter of the next); then compound 3.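

This pair is the first shown that differs in one place, which gives a direct reading of this position in this assay. Replacing cyclopropyl with ethyl on a saturated chain carbon bound to an aromatic nitrogen, which can also be read as cyclopropylmethyl becoming propyl, gives a 3.9-fold higher number from compound 2 to compound 3 (0.59 log units; beyond the scatter) and thus a modest but real loss of potency. The position is therefore sensitive to a small exchange, since losing a single carbon and the three-membered ring is enough to move the number beyond the scatter, and no measurement shown here gives a reason for the step.

Going by these compounds, with a single pair, the ring and the carbon count cannot be separated, so it remains open whether a cyclobutyl in the place of the cyclopropyl, or a longer chain such as butyl in the place of the propyl, would lie closer to compound 2 or to compound 3. On these data alone, it is also open whether an amine or a carboxylic acid at this position would be tolerated, and whether the same exchange would give a similar step on the core of compound 1.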